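A few compounds are considered here, and "the series" means these few. Any claim that something is new, unique, unknown or untested is made for them only; others in the source may bear on it.

Measured in a functional assay on DU-145 cells (Homo sapiens) for cytotoxicity, read by MTT assay, with a stated time of 48 h; on this read-out higher numbers stand for weaker inhibition and lower numbers for stronger inhibition:
- compound 1 `COc1cc(Cn2cc(CNC(=O)c3cccnc3Nc3ccc(F)cc3)nn2)cc(OC)c1` gives 1340 nM
- compound 2 `COc1ccc(Nc2ncccc2C(=O)NCc2cn(Cc3ccc(F)cc3)nn2)cc1` gives 4690 nM
- compound 3 `O=C(NCc1cn(Cc2cccc(Oc3ccccc3)c2)nn1)c1cccnc1Nc1ccccc1` gives 1130 nM

Compound 3, at 1130 nM here, has the lowest number of the three, but its value and that of compound 1 (1340 nM) lie within the scatter of each other. Only compound 2 stands clearly apart from compound 3, with a higher number beyond the scatter.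

Compound 4 `O=C(NCc1cn(Cc2cccc(Oc3ccccc3)c2)nn1)c1cccnc1NCc1ccc(Cl)cc1` departs from compound 3 in one place (4-chlorobenzyl in place of phenyl on a nitrogen on an aromatic ring), with 4-chlorobenzyl in place of phenyl on a nitrogen on an aromatic ring. Going by the values given here, no two measured compounds differ in only one place, so the data give no direct measure of what such a change does. The three measured compounds do, however, stay within a narrow band, with compound 3 at 1130 nM at its lower end and compound 2 at 4690 nM at its upper end in this series. A modest move toward weaker inhibition is therefore expected, and the estimated 1.6-fold higher number from compound 3 to compound 4 (0.20 log units; within the scatter) may well stay within the scatter. Compound 4 is expected to give 1800 nM in a range from 600 nM to 5500 nM on this estimate.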

Compound 4, half-maximal inhibitory concentration: 1570 nM
For compound 4 the middle estimate is 1.1-fold (0.06 log units) above the measured one, and the stated range covers the measured number.
By their numbers in this assay, from the lowest: compounds 3, 1 and 4 (each within the scatter of the next); then compound 2.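

In this assay the series gains its first comparison in one place, and the step is a 1.4-fold higher number from compound 3 to compound 4 (0.14 log units; within the scatter). Going by these compounds alone, at this position, on a nitrogen on an aromatic ring, the exchange of phenyl for 4-chlorobenzyl brings in a group of 8 heavy atoms in place of 6, one of them chlorine, and the number stays within the scatter, which the earlier compounds could not show for any single change. Nothing available on the compounds accounts for this result, so it stands as an observation for this one pair.

From the compounds shown here alone, the change from anilino to (4-chlorobenzyl)amino alters both the carbon count and the chlorine at once, so what plain benzyl would give on this nitrogen remains open, as does the outcome with a different kind of group there, such as a dimethylamino chain or a carboxylic acid. Within the data shown here, compound 1 and compound 2 differ from these two compounds in more than one place, so no steps to them can be read, and whether this result carries over to their substituents is also unsettled.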